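Swapping a dimethoxypyrimidine for an ethoxyphenyl in cytotoxicity

The source may report more compounds than this note shows. Statements on the series, on what has been measured and on what is new or still open speak of the compounds shown alone.

Measured compounds in an ADME assay on HepG2 cells (Homo sapiens) for cytotoxicity, read by CellTiter-Glo and resazurin assay, with a stated time of 72 h; a higher number here means that more compound is needed for the effect, a lower number that less compound is needed:
compound 1 `CC(C)N(Cc1cccc(OCCCCCC(=O)O)c1)C(=O)c1ccc(-c2ccsc2)cc1` gives > 26000 nM
compound 2 `CC(C)N(Cc1cccc(OCCCCCC(=O)O)c1)C(=O)c1ccc(-c2cccc(C(F)(F)F)c2)cc1` gives > 26000 nM
compound 3 `CCOC(=O)CCCCCOc1cccc(CN(C(=O)c2ccc(-c3cnc(OC)nc3OC)cc2)C(C)C)c1` gives > 26000 nM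

Each of these three values is a limit of the assay rather than a number. For compound 1 the result is a limit. For compound 2 the result is likewise a limit. For compound 3 the result is again only a limit, so compound 3 stands with the other two rather than apart from them. Within the data shown here, the one measured step, a step that the two limits leave unreadable from compound 1 to compound 2, cannot be sized for that reason.

Compound 4 is `CCOC(=O)CCCCCOc1cccc(CN(C(=O)c2ccc(-c3cccc(OCC)c3)cc2)C(C)C)c1`. It differs from compound 3 in one place: 3-ethoxyphenyl in place of 2,4-dimethoxypyrimidin-5-yl on an aromatic carbon. Among the measured compounds shown here, no measured step touches this exact exchange; the only step recorded sits elsewhere and is itself unreadable. What bears on the expectation is the limit of > 26000 nM in this assay, at which 3 of the 3 values shown sit, since every compound of the set sits at it. A step beyond the scatter in either direction is therefore not expected.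

Compound 4 is expected to show 30000 nM, between 13000 nM and 100000 nM. The step that the limit leaves unreadable from compound 3 to compound 4 is estimated to be none beyond the scatter, and a further limit is the most probable outcome.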

Compound 4, half-maximal effective concentration: > 22300 nM
Compound 4: only a limit was reported; the forecaster's own chance of this, stated with the estimate: 85%; the middle value is on the limit's open side.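

In this assay compound 3 gives > 26000 nM, which is a limit of the assay. Compound 4 gives > 22300 nM, also a limit. Among these compounds, no step from one to the other can be read. The compounds shown leave open whether exchanging 2,4-dimethoxypyrimidin-5-yl for 3-ethoxyphenyl changes cytotoxicity at all.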